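Triazolopyrimidine-type series: amine change at the aromatic nitrogen

The source may report more compounds than this note shows. Statements on the series, on what has been measured and on what is new or still open speak of the compounds shown alone.

Measured so far:
compound 1, `OC1CCC(Nc2nc(-c3ccccc3)nc3c2nnn3Cc2ccccc2F)CC1` — 1850000 nM
compound 2, `CCNc1nc(-c2ccccc2)nc2c1nnn2Cc1ccccc1Cl` — 463000000 nM

Two compounds of the shared core have been run in an assay on isolated protein for binding affinity to adenosine receptor A1 (Bos taurus); on this read-out higher numbers stand for weaker inhibition and lower numbers for stronger inhibition. Compound 1 gives 1850000 nM and compound 2 gives 463000000 nM. Compound 2 thus stands at the highest number of the two, and its gap to compound 1 lies well beyond the usual scatter of repeated measurements; both numbers sit very far up the scale.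

Compound 3, `OC1CCC(Nc2nc(-c3ccccc3)nc3c2nnn3Cc2ccccc2Cl)CC1`, is not yet measured. It is drawn from compound 2 by the change (4-hydroxycyclohexyl in place of ethyl on a nitrogen on an aromatic ring). Among the measured compounds shown here, no step between measured compounds describes this exact exchange, so the expectation rests on the values of compound 1 and compound 2 only. Since compound 1, which carries the entering amine group, gives 1850000 nM, a large move down from compound 2 is expected for compound 3, plausibly a step of a 150-fold lower number from compound 2 to compound 3 (2.19 log units; beyond the scatter) in this assay. Compound 3 is therefore estimated at 3000000 nM, with a range from 300000 nM to 60000000 nM, in this assay.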

Compound 3, inhibition constant: 3100000 nM
Compound 3: the middle estimate sits 1.0-fold (0.01 log units) below what was measured, and the stated range covers the measured number.
By their numbers in this assay, from the lowest: compounds 1 and 3 (each within the scatter of the next); then compound 2.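

With the chloro group held constant, 4-hydroxycyclohexyl in place of ethyl on a nitrogen on an aromatic ring gives a 150-fold lower number from compound 2 to compound 3 (2.17 log units; beyond the scatter) in this assay and thus attaches a large step to this amine position, which the earlier pair could not do because it also differed in the halogen. Chloro in place of fluoro on an aromatic carbon, with the (4-hydroxycyclohexyl)amino group held constant, gives a 1.7-fold higher number from compound 1 to compound 3 (0.22 log units; within the scatter) and stays within the scatter, so this pair shows no readable difference between the two halogens. No measured evidence bears on what lies behind the size of the amine step.

The compounds shown leave open whether the step goes with the six-membered carbon ring or with the hydroxyl, and plain cyclohexyl or a longer chain such as butyl on the same nitrogen would separate the two. Also open, as far as these compounds go, is whether the exchange of fluoro and chloro reads the same with ethyl on that nitrogen, and how a methoxy group on the same aromatic carbon would compare with either halogen.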